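Trading fluoro for trifluoromethyl on a second aromatic ring

A few compounds are considered here, and "the series" means these few. Any claim that something is new, unique, unknown or untested is made for them only; others in the source may bear on it.

Compound 1 `O=C1/C(=C/c2cccnc2)CN(S(=O)(=O)c2ccc(C(F)(F)F)cc2)C/C1=C\c1ccccc1F`: 4500 nM
Compound 2 `O=C1/C(=C/c2cccnc2)CN(S(=O)(=O)c2ccc(F)cc2)C/C1=C\c1ccccc1F`: 15300 nM

In a functional assay on QGY-7703 cells (Homo sapiens) for cytotoxicity, read by MTT assay, with a stated time of 24 h (a lower number here means a stronger inhibitor, a higher number a weaker inhibitor), compound 2 gives 15300 nM, the higher of the two numbers, which makes it the weaker inhibitor of the pair. The unmeasured compound 3 `O=C1/C(=C/c2cccnc2)CN(S(=O)(=O)c2ccc(F)cc2)C/C1=C\c1ccccc1C(F)(F)F` differs from compound 2 in one place: trifluoromethyl in place of fluoro on an aromatic carbon. In words, 2-fluorophenyl becomes 2-(trifluoromethyl)phenyl.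

For the measured compounds named here, only one measured step bears on this: a 3.4-fold higher number from compound 1 to compound 2 (0.53 log units; beyond the scatter). That step is modest and swaps the same two groups in the opposite sense, at a different aromatic carbon. Read backwards, it links trifluoromethyl with the lower number, but a single step elsewhere in the molecule is weak evidence. A modest lowering in the same direction is therefore expected, and the expected change is a 2.2-fold lower number from compound 2 to compound 3 (0.34 log units; beyond the scatter). For compound 3 the estimated value is 7000 nM, with an expected range of 2500 nM to 18000 nM.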

Compound 3, half-maximal inhibitory concentration: 6030 nM
The estimate for compound 3 lay 1.2-fold (0.06 log units) above the measured number; measured number inside the range.
By their numbers in this assay, from the lowest: compounds 1 and 3 (each within the scatter of the next); then compound 2.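

In this assay, replacing 2-fluorophenyl with 2-(trifluoromethyl)phenyl gives a 2.5-fold lower number from compound 2 to compound 3 (0.40 log units; beyond the scatter) and shows that this position also responds to the exchange, with a step beyond the usual scatter. The earlier step, a 3.4-fold higher number from compound 1 to compound 2 (0.53 log units; beyond the scatter) on the other aromatic ring, ran in the matching sense, so among the compounds shown, trifluoromethyl goes with the lower number at both places where it is exchanged with fluoro. No measurement here accounts for why the number moves at either place.

The compounds shown leave open whether another group at this position, such as chloro, methoxy or an amine, would give a similar number. They also leave open how a compound carrying trifluoromethyl at both places would compare.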